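Furan to Thiophene on Two Different Cores

The source may hold more compounds than are shown below. What is called first, only, known or untested is meant among the compounds shown, and "the series" means these compounds.

Compound 1 `O=C(CCCCCCc1ccccc1)c1nc(-c2ccco2)no1` and compound 2 `O=C(CCCCCCc1ccccc1)c1nc(-c2cccs2)no1` share one core and differ only in the ring that hangs from it. In an assay for inhibition of Fatty-acid amide hydrolase 1 (Rattus norvegicus), at pH 9.0 (a lower number here means a stronger inhibitor, a higher number a weaker inhibitor), compound 1 gives 1 nM, and compound 2 gives 1.6 nM. The change between them is thiophen-2-yl in place of furan-2-yl on an aromatic carbon, and it made a step of a 1.6-fold higher number from compound 1 to compound 2 (0.20 log units; within the scatter).

Compound 3 `O=C(CCCCCCc1ccccc1)c1ncc(-c2ccco2)s1` carries the same furan-2-yl group on a different core; how the two cores differ is not broken down here. In this assay compound 3 gives 1500 nM, the highest of the three numbers, and its distance from compound 1 and from compound 2 lies beyond the usual scatter.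

Compound 4 `O=C(CCCCCCc1ccccc1)c1ncc(-c2cccs2)s1` has not yet been measured. It differs from compound 3 by thiophen-2-yl in place of furan-2-yl on an aromatic carbon. Within the data shown here, this is the same kind of change as the one from compound 1 to compound 2, not the same: there the place was between two ring nitrogen atoms, two ring bonds from the ring oxygen, on a ring with 2 nitrogen and 1 oxygen; here it is next to the ring sulfur, two ring bonds from the ring nitrogen, on a ring with 1 nitrogen and 1 sulfur. Both places are two ring bonds from the ring atom that bears a large group.

The expected step is a 1.3-fold higher number from compound 3 to compound 4 (0.12 log units; within the scatter), resting on the earlier step of a 1.6-fold higher number from compound 1 to compound 2 (0.20 log units; within the scatter) having stayed within the scatter. In this assay compound 4 is estimated at 2000 nM, with a likely range from 700 nM to 6000 nM.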

Compound 4, inhibition constant: 2000 nM
Compound 4: the middle estimate sits on the measured number at the digits printed, and the stated range covers the measured number.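

In this assay, thiophen-2-yl in place of furan-2-yl on the core of compound 3 made a step of a 1.3-fold higher number from compound 3 to compound 4 (0.12 log units; within the scatter), so the swap left no readable mark on this second core. Set beside the earlier step, the change carried from one core to the other with no difference that can be told apart: the same change on two cores in this assay, a 1.6-fold higher number (0.20 log units; within the scatter) from compound 1 to compound 2 and a 1.3-fold higher number (0.12 log units; within the scatter) from compound 3 to compound 4, 1.2-fold (0.08 log units) apart, within the scatter of two such steps

Among these compounds, this shows only that a change too small to read on one core stayed too small to read on the other; it does not show that a change with a step beyond the scatter would carry over in the same way, and it rests on just two cores and one pair of groups, all on the same chain.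

The compounds shown leave open whether a phenyl or pyridin-2-yl ring in the place of furan-2-yl would give the same step on both cores. They also leave open whether a carboxylic acid or an amine on that ring, or a shorter chain ending in the phenyl group, would travel between the cores as quietly as the thiophen-2-yl swap did.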